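The compounds below may be only part of what the source reports. "The series", "measured", "known", "first", "only" and "open" are said of these compounds alone.

Notes on the series. Compound 2 `CCC1(CCCCN2CCN(c3ccc(Cl)cc3)CC2)C(=O)Nc2ccccc21` and compound 1 `CCC1(CCCCN2CCN(c3ccc(Cl)cc3)CC2)C(=O)Nc2cc(F)ccc21` share one core; in an assay on membranes from frontal cortex for displacement of a labelled ligand from Adrenergic receptor alpha-1 (Rattus norvegicus), read by scintillation counting, with a stated time of 45 min (on this read-out lower numbers stand for stronger inhibition and higher numbers for weaker inhibition), compound 2 gives 93 nM and compound 1 gives 215 nM. The change between them is fluoro in place of hydrogen on an aromatic carbon, and it made a step of a 2.3-fold higher number from compound 2 to compound 1 (0.36 log units; beyond the scatter).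

Compound 3 `O=C1Nc2ccccc2C1CCCCN1CCN(c2ccccn2)CC1` sits on a second core; how the two cores differ is not broken down here. In this assay compound 3 gives 130 nM, a number within the scatter of compound 2 and of compound 1.

Compound 4 `O=C1Nc2cc(F)ccc2C1CCCCN1CCN(c2ccccn2)CC1` is not yet measured. Its change from compound 3 is fluoro in place of hydrogen on an aromatic carbon, the same change, at the same place, as from compound 2 to compound 1. On that single precedent, compound 4 is expected to move by about a 2.3-fold higher number from compound 3 to compound 4 (0.36 log units; beyond the scatter) in this assay, resting on the step of a 2.3-fold higher number from compound 2 to compound 1 (0.36 log units; beyond the scatter). Compound 4 is therefore estimated at 300 nM, with a likely range from 150 nM to 600 nM.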

Compound 4, inhibition constant: 33 nM
Compound 4: the middle estimate sits 9.1-fold (0.96 log units) above what was measured; the whole stated range lies above it.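

In this assay, fluoro in place of hydrogen on an aromatic carbon gives a step of a 3.9-fold lower number from compound 3 to compound 4 (0.60 log units; beyond the scatter). Set beside the earlier step, the same change at the same place runs in opposite directions on the two cores: the same change on two cores in this assay, a 2.3-fold higher number (0.36 log units; beyond the scatter) from compound 2 to compound 1 and a 3.9-fold lower number (0.60 log units; beyond the scatter) from compound 3 to compound 4, 9.1-fold (0.96 log units) apart, beyond the scatter of two such steps

In this series, a step read on one core therefore does not carry over to the other, even in direction; with one pair per core, this shows that the outcome depends on the core, but not which feature of the core is responsible or how other cores would behave.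

Which part of the difference between the two cores goes with the reversal stays open. Also open, as far as these compounds go, is whether methoxy or a nitrile at the same place would split between the two cores in the same way.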